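This account rests on a few compounds, and the source may have more. Where it says the series, first, only, none or still open, it means among the compounds named here.

The study compares two cores. Compound 1, `CC(=O)c1c(NNc2ccc(Cl)cc2)cc(C)oc1=O`, and compound 2, `CC(=O)c1c(NNc2ccc(Br)cc2)cc(C)oc1=O`, share one core, while compound 3, `Cc1cc2nn(-c3ccc(Cl)cc3)c(C)c2c(=O)o1`, and compound 4, `Cc1cc2nn(-c3ccc(Br)cc3)c(C)c2c(=O)o1`, share another. The difference between the two cores is not broken down here.

In a functional assay on the whole organism for inhibition, with Rattus norvegicus as the target, read by paw edema, with a stated time of 4 h, at a dose of 50 mg/kg (a lower number here means less inhibition, a higher number more inhibition at the dose given (going by the name of the read-out)), compound 1 gives 28.4%. Compound 2 differs from compound 1 in one place: bromo in place of chloro on an aromatic carbon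
In this assay compound 2 gives 18.6%, a step of a number 9.8 percentage points lower from compound 1 to compound 2 (within the scatter). Compound 3 gives 38.2% in this assay; of the three measured numbers it is the highest, with compound 1 lying within the scatter of it and compound 2 beyond the scatter.

Compound 4 differs from compound 3 in one place: bromo in place of chloro on an aromatic carbon
This is the same change as that made from compound 1 to compound 2, and the place reads the same in both cases, on an aromatic carbon of a six-membered aromatic ring of carbon only, para to a large group. Among the compounds shown the change occurs twice in all.

For compound 4 the step in this assay is expected to be a number 8.2 percentage points lower from compound 3 to compound 4 (within the scatter). Among the compounds with values here, this expectation rests on the earlier step of a number 9.8 percentage points lower from compound 1 to compound 2 (within the scatter), which lay within the scatter, and on the fact that only this one measured pair shows the change. For compound 4 the estimated result in this assay is 30%, with a range from 18% to 42%.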

Compound 4, a percentage reported as inhibition, in the whole organism at one dose (the size of the read-out at that dose, not a potency): 38.2%
Compound 4: middle estimate off by 8.2 percentage points, on the low side; measured number inside the range.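

In this assay the exchange of chloro for bromo on the core of compound 3 gives no change at the digits printed from compound 3 to compound 4 (within the scatter), and this sits within the scatter of the step seen on the core of compound 1: the same change on two cores in this assay, a number 9.8 percentage points lower (within the scatter) from compound 1 to compound 2 and no change at the digits printed (within the scatter) from compound 3 to compound 4, 9.8 percentage points apart, within the scatter of two such steps

So, in this one assay and at this one dose, the change can be carried from one core to the other without either step leaving the scatter. This does not show that the two cores respond to the change identically, since both steps are small enough that neither a real effect of the exchange nor a real difference between the cores can be read from them, and two pairs cannot say what a further core would do.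

The compounds shown carry only chloro or bromo at this place on the aromatic ring, so it stays open how either core would answer to a fluoro group, a methoxy group, an amine or a carboxylic acid there. Going by these compounds, the methyl groups on both cores and the acetyl group on the core of compound 1 stay the same throughout, so what a longer chain in their place would do in this assay also remains open.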